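Removing the Chloro Group from a Hydrazone Analogue

A few compounds are considered here, and "the series" means these few. Any claim that something is new, unique, unknown or untested is made for them only; others in the source may bear on it.

Compound 1 `COc1ccc(OC)c(/C=C/c2nnc(Nc3ccc(Cl)cc3)o2)c1` is the stronger of the two measured compounds: in a functional assay on Hs-578T cells (Homo sapiens) for antiproliferative activity, read by sulforhodamine B assay, with a stated time of 48 h (on this read-out lower numbers stand for stronger inhibition of growth and higher numbers for weaker inhibition of growth), compound 1 gives 8010 nM. Compound 2 `COc1ccc(OC)c(/C=C/C(=O)N/N=C/c2ccc(Cl)cc2)c1` keeps the dimethoxystyryl piece but joins it to the chlorophenyl group through a different linker. In this assay compound 2 is recorded only as a limit, > 100000 nM, not as a number, and it sits at the weak edge of the values shown (the limit of > 100000 nM in this assay, at which 1 of the 2 values shown sits).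

Compound 3 `COc1ccc(OC)c(/C=C/C(=O)N/N=C/c2ccccc2)c1` differs from compound 2 by hydrogen in place of chloro on an aromatic carbon, in words hydrogen in place of chloro on an aromatic carbon. Among the measured compounds shown here, no measured pair shows this change here. For the measured compounds named here, since compound 2 already sits at a limit, only a step beyond the scatter towards stronger inhibition would yield a number, and removing the chloro is expected to give no step of that size. Compound 3 is therefore estimated at 100000 nM, with a range from 40000 nM to 300000 nM, an expected step of a number no higher from compound 2 to compound 3 (the limit leaves the size open).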

Compound 3, concentration for total growth inhibition: > 100000 nM
Compound 3: a limit, no number; the forecaster's own chance of this, stated with the estimate: 80%; the middle value sits exactly at the limit.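

Compound 2 and compound 3 are each recorded in this assay only as a limit, not a number, so no step between them can be read: the limit of > 100000 nM in this assay, at which 2 of the 3 values shown sit.

The compounds shown leave open whether going from 4-chlorophenyl to phenyl changes growth inhibition at all.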